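Working notes: oxan-4-yl in place of 3,3-difluorocyclopentyl

A few compounds are considered here, and "the series" means these few. Any claim that something is new, unique, unknown or untested is made for them only; others in the source may bear on it.

Measured in a physicochemical assay for solubility, using the shake flask method, measured as kinetic solubility, with a stated time of 20 h, at pH 2; on this read-out lower numbers stand for lower solubility and higher numbers for higher solubility:
- compound 1 `FC(F)(F)c1ccc(Nc2cc3[nH]c(-c4cccc(C(F)(F)F)c4)nc3cn2)nc1`: < 5000 nM (a limit of the assay)
- compound 2 `FC1(F)CCC(c2nc3cnc(Nc4ccc(C(F)(F)F)cn4)cc3[nH]2)C1`: 185000 nM

Going by the values given here, compound 2 holds the only true number so far, 185000 nM. Compound 1 sits at a limit and has no number: the limit of < 5000 nM in this assay, at which 1 of the 2 values shown sits. Among the compounds with values here, the single measured step, an at least 37-fold higher number from compound 1 to compound 2 (1.56 log units; beyond the scatter), is large and beyond the scatter. Going on to compound 3 `FC(F)(F)c1ccc(Nc2cc3[nH]c(C4CCOCC4)nc3cn2)nc1`, oxan-4-yl takes the place of 3,3-difluorocyclopentyl on an aromatic carbon: oxan-4-yl in place of 3,3-difluorocyclopentyl on an aromatic carbon. Within the data shown here, no measured step exchanges one non-aromatic ring for another. The step of an at least 37-fold higher number from compound 1 to compound 2 (1.56 log units; beyond the scatter) removed 3-(trifluoromethyl)phenyl, so its size is not expected to carry over. In this assay, no change beyond the scatter is expected, in either direction. The expected step is a 1.1-fold higher number from compound 2 to compound 3 (0.03 log units; within the scatter). For compound 3 the estimated value is 200000 nM, with an expected range of 70000 nM to 500000 nM.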

Compound 3, solubility: 196000 nM
For compound 3 the middle estimate is 1.0-fold (0.01 log units) above the measured one; measured number inside the range.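

In this assay, the position on an aromatic carbon between two ring nitrogen atoms now takes two different non-aromatic rings, oxan-4-yl and 3,3-difluorocyclopentyl, and the exchange stays within the scatter: a 1.1-fold higher number from compound 2 to compound 3 (0.03 log units; within the scatter). Replacing 3-(trifluoromethyl)phenyl with oxan-4-yl also gives a large step, an at least 39-fold higher number from compound 1 to compound 3 (1.59 log units; beyond the scatter), so this size is no longer seen with 3,3-difluorocyclopentyl alone. Compound 1 has no true number, and its value is a limit: the limit of < 5000 nM in this assay, at which 1 of the 3 values shown sits.

Still open is how far this tolerance extends, since both non-aromatic rings shown carry no net charge; a piperidine ring with its amine, or a ring bearing a carboxylic acid, would test that. From the compounds shown here alone, an open-chain group such as a longer alkyl chain at this position also remains untested.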